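One more methylene between chain and phenyl ring

The compounds below may be only part of what the source reports. "The series", "measured", "known", "first", "only" and "open" are said of these compounds alone.

Three amides on a shared core have been measured in an assay for inhibition of acyl-CoA:cholesterol acyltransferase (Oryctolagus cuniculus), using microsomes; a lower number here means a stronger inhibitor, a higher number a weaker inhibitor. Compound 1 `CCCCCCCCC(C)(C)C(=O)Nc1c(C)cc(C)c2c1OC(C)(C)C2` gives 140 nM in this assay. Compound 2 `CCCCCCCCCCCCC(C)(C)C(=O)Nc1c(C)cc(C)c2c1OC(C)(C)C2` gives 33 nM in this assay. Compound 3 `Cc1cc(C)c(NC(=O)C(C)(C)CCCCc2ccccc2)c2c1CC(C)(C)O2` gives 210 nM in this assay, the highest of the three numbers, although its gap to compound 1 lies within the scatter and only its gap to compound 2 lies beyond it.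

Compound 4 `Cc1cc(C)c(NC(=O)C(C)(C)CCCCCc2ccccc2)c2c1CC(C)(C)O2` differs from compound 3 in one place: benzyl in place of phenyl on a saturated chain carbon, five bonds along the chain from a carbonyl carbon. The chain carrying the aromatic ring therefore grows by one carbon.

Two measured steps speak to chain length. Lengthening the saturated chain gave a 4.2-fold lower number from compound 1 to compound 2 (0.63 log units; beyond the scatter). Replacing a long chain by a shorter one ending in phenyl gave a 6.4-fold higher number from compound 2 to compound 3 (0.80 log units; beyond the scatter), whereas a 1.5-fold higher number from compound 1 to compound 3 (0.18 log units; within the scatter) shows that a phenyl at the end of a shorter chain roughly matches a plain butyl. A single added carbon is a far smaller change than either of these, so a small move toward a lower number, likely within the scatter, is expected.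

Compound 4 is therefore expected to give about 150 nM in this assay, between 60 nM and 400 nM, which corresponds to an expected step of a 1.4-fold lower number from compound 3 to compound 4 (0.15 log units; within the scatter).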

Compound 4, half-maximal inhibitory concentration: 120 nM
Compound 4: the middle estimate sits 1.3-fold (0.10 log units) above what was measured, within the range that was stated.
By their numbers in this assay, from the lowest: compound 2; then compounds 4, 1 and 3 (each within the scatter of the next).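

In this assay, among these compounds, the extra carbon in the chain carrying the aromatic ring gives a 1.8-fold lower number from compound 3 to compound 4 (0.24 log units; within the scatter), so at this place, five bonds along the chain from the carbonyl carbon, benzyl in place of phenyl produces no step that can be told from the scatter. The new compound also sits level with the plain saturated chain of compound 1, as a 1.2-fold lower number from compound 1 to compound 4 (0.07 log units; within the scatter) shows, but it stays clearly apart from the long saturated chain, with a 3.6-fold higher number from compound 2 to compound 4 (0.56 log units; beyond the scatter), so neither chain ending in phenyl among these compounds matches compound 2, and the added carbon does not change that picture. Nothing available here accounts for these steps in terms of a measured property.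

Whether a longer chain ending in phenyl would close the gap to compound 2 remains open, since the two phenyl compounds shown cannot establish a trend with chain length. Also open, going by these compounds, is how a chain ending in an amine or a carboxylic acid in place of phenyl, or a phenyl ring carrying a fluorine, would behave in this assay.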